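This account rests on a few compounds, and the source may have more. Where it says the series, first, only, none or still open, it means among the compounds named here.

Compound 1 `OC[C@H]1O[C@@H](n2cnc3c(NCc4ccccc4Br)ncnc32)[C@H](O)[C@@H]1O` in a functional assay on HL-60 cells (Homo sapiens) for antiproliferative activity, with a stated time of 72 h; a higher number here means a weaker inhibitor, a lower number a stronger inhibitor: 6600 nM
Compound 2 `COc1ccc(CNc2ncnc3c2ncn3[C@@H]2O[C@H](CO)[C@@H](O)[C@H]2O)c(OC)c1` in this assay: 39000 nM
Compound 3 `COc1cc(CNc2ncnc3c2ncn3[C@@H]2O[C@H](CO)[C@@H](O)[C@H]2O)cc(OC)c1` in this assay: 20200 nM

Compound 3 sits at the high end of this small set alongside compound 2, and the two cannot be told apart, with a 1.9-fold lower number from compound 2 to compound 3 (0.29 log units; within the scatter). Compound 1 stands apart from it, with a 3.1-fold higher number from compound 1 to compound 3 (0.49 log units; beyond the scatter), and also from compound 2, with a 5.9-fold higher number from compound 1 to compound 2 (0.77 log units; beyond the scatter).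

The next compound is compound 4 `OC[C@H]1O[C@@H](n2cnc3c(NCc4ccc(F)cc4Cl)ncnc32)[C@H](O)[C@@H]1O`, which carries 2-chloro-4-fluorophenyl in place of 3,5-dimethoxyphenyl on a saturated chain carbon bound to a nitrogen on an aromatic ring. Among the measured compounds shown here, no measured step makes this exact change. The nearest evidence is the replacement of 2-bromophenyl by 3,5-dimethoxyphenyl, which gave a 3.1-fold higher number from compound 1 to compound 3 (0.49 log units; beyond the scatter). If the new halogenated phenyl group tracks 2-bromophenyl, a modest step of similar size in the opposite direction is expected in this assay, although only one halogenated compound supports this. The expected change is a 2.5-fold lower number from compound 3 to compound 4 (0.40 log units; beyond the scatter). The estimate for compound 4 is 8000 nM, with an expected range of 3000 nM to 20000 nM.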

Compound 4, half-maximal inhibitory concentration: 9000 nM
Compound 4: middle estimate off by 1.1-fold (0.05 log units), on the low side; the measured number falls inside the stated range.
By their numbers in this assay, from the lowest: compounds 1 and 4 (each within the scatter of the next); then compounds 3 and 2 (each within the scatter of the next).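

In this assay, 2-chloro-4-fluorophenyl on a saturated chain carbon bound to a nitrogen on an aromatic ring gives a 2.2-fold lower number from compound 3 to compound 4 (0.35 log units; beyond the scatter) and a 4.3-fold lower number from compound 2 to compound 4 (0.64 log units; beyond the scatter), so a second halogenated phenyl group now stands apart from both dimethoxyphenyl groups. Against 2-bromophenyl there is a 1.4-fold higher number from compound 1 to compound 4 (0.13 log units; within the scatter), which lies within the scatter, so the two halogenated compounds cannot be told apart, and among these four compounds none goes against the split between halogenated and dimethoxyphenyl groups. Nothing available explains this split.

The compounds shown leave open whether the halogens themselves matter or whether the methoxy groups are what separates the sets, a question that an unsubstituted phenyl group could address. From the compounds shown here alone, how an amine or a carboxylic acid on the phenyl ring would read out at this position also remains open.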